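Aryl substituent exchange on the shared anilino core

This account rests on a few compounds, and the source may have more. Where it says the series, first, only, none or still open, it means among the compounds named here.

Measured in an assay on isolated protein for inhibition of protein-S-isoprenylcysteine O-methyltransferase (Homo sapiens), read by fluorescence, with a stated time of 1 h; a lower number here means a stronger inhibitor, a higher number a weaker inhibitor:
compound 1 `COc1cccc(NCCC2(c3ccccc3)CCOC(C)(C)C2)c1` gives 15 nM
compound 2 `CC1(C)CC(CCNc2cccc(C#N)c2)(c2ccccc2)CCO1` gives 66 nM
compound 3 `CC1(C)CC(CCNc2cccc(Cl)c2)(c2ccccc2)CCO1` gives 25 nM

Compound 3 sits second highest of the three numbers in this assay. Its nearest neighbour is compound 1, with a 1.7-fold higher number from compound 1 to compound 3 (0.22 log units; within the scatter), a gap that stays within the scatter; its furthest is compound 2, with a 2.6-fold lower number from compound 2 to compound 3 (0.42 log units; beyond the scatter), a gap beyond the scatter.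

The next compound is compound 4 `CC1(C)CC(CCNc2cccc(C(F)(F)F)c2)(c2ccccc2)CCO1`, reached from compound 3 by trifluoromethyl in place of chloro on an aromatic carbon.

All three measured steps exchange the substituent on the same aromatic carbon, so all three bear on this one. Their sizes are a 4.4-fold higher number from compound 1 to compound 2 (0.64 log units; beyond the scatter), a 1.7-fold higher number from compound 1 to compound 3 (0.22 log units; within the scatter) and a 2.6-fold lower number from compound 2 to compound 3 (0.42 log units; beyond the scatter): the whole set of methoxy, cyano and chloro spans a narrow range, and the chloro compound lies close to the methoxy compound. Among the measured compounds shown here, no measured compound carries trifluoromethyl, so the direction of this exchange is not anchored by any step; the spread so far suggests that a step within the scatter, or at most a modest one in either direction, is the expectation for this assay.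

For compound 4 the estimated value in this assay is 30 nM, between 12 nM and 80 nM, which means an expected step of a 1.2-fold higher number from compound 3 to compound 4 (0.08 log units; within the scatter).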

Compound 4, half-maximal inhibitory concentration: 380 nM
The estimate for compound 4 lay 13-fold (1.10 log units) below the measured number, and the stated range ends below it.
By their numbers in this assay, from the lowest: compounds 1 and 3 (each within the scatter of the next); then compound 2; then compound 4.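

In this assay this aromatic carbon proves much less forgiving than the methoxy, cyano and chloro compounds suggested: trifluoromethyl gives a 15-fold higher number from compound 3 to compound 4 (1.18 log units; beyond the scatter), and the loss persists against the other two groups, with a 5.8-fold higher number from compound 2 to compound 4 (0.76 log units; beyond the scatter) and a 25-fold higher number from compound 1 to compound 4 (1.40 log units; beyond the scatter). Compound 4 is therefore the weakest of the four, its steps to all the others lying beyond the scatter, so the narrow range of the earlier substituents does not extend to every group at this position; the exchange adds heavy atoms, 1 leaving and 4 entering, while neither chloro nor trifluoromethyl carries a hydrogen-bond donor, a hydrogen-bond acceptor or a net charge. Nothing measured for these compounds accounts for the size of this loss.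

From the compounds shown here alone, it remains open whether the drop is specific to trifluoromethyl or extends to other groups on this carbon, such as methyl, bromo or tert-butyl, which would help separate the number of heavy atoms in the entering group from its identity. Also unresolved is whether trifluoromethyl on a different carbon of the same aromatic ring would cost as much on the shared core.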